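Benzylation of the remaining hydroxyl in a second core

The source may hold more compounds than are shown below. What is called first, only, known or untested is meant among the compounds shown, and "the series" means these compounds.

Compound 1 `CCCCCCCO[C@@H]1[C@@H](O)[C@@H](OCc2ccccc2)O[C@@H]2CO[C@@H](c3ccc(OC)cc3)O[C@@H]12` and compound 2 `CCCCCCCO[C@@H]1[C@@H](OCc2ccccc2)[C@@H](OCc2ccccc2)O[C@@H]2CO[C@@H](c3ccc(OC)cc3)O[C@@H]12` share one core; compound 3 `CCCCCCCO[C@@H]1[C@@H](O)[C@@H](OCc2ccccc2)O[C@H](CC(C)C)[C@H]1O` and compound 4 `CCCCCCCO[C@H]1[C@H](O)[C@@H](CC(C)C)O[C@H](OCc2ccccc2)[C@@H]1OCc1ccccc1` share another, and the difference between the two cores is not broken down here. In a functional assay on MCF7 cells (Homo sapiens) for cytotoxicity, in the presence of a further agent that is not named here (a lower number here means that less compound is needed, a higher number that more compound is needed for the effect), compound 1 gives 2.5 ug/mL. For compound 2 this assay reports only a limit, > 20 ug/mL. From the compounds shown here alone, the change made is benzyl in place of hydrogen on an oxygen on a saturated carbon; it gave an at least 8.0-fold higher number from compound 1 to compound 2 (0.90 log units; beyond the scatter), a step whose full size stays open because of the limit of > 20 ug/mL in this assay, at which 1 of the 3 values shown sits. In this assay compound 3 gives 6 ug/mL. Compound 4 carries the same change, (benzyl in place of hydrogen on an oxygen on a saturated carbon), at a place described in identical words. For compound 4 the step is expected to be of at least the same size, a 6.7-fold higher number from compound 3 to compound 4 (0.82 log units; beyond the scatter), resting on an at least 8.0-fold higher number from compound 1 to compound 2 (0.90 log units; beyond the scatter). For compound 4 the expected value in this assay is therefore 40 ug/mL, most likely reported again only as a limit.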

Compound 4, half-maximal effective concentration: 6 ug/mL
The estimate for compound 4 lay 6.7-fold (0.82 log units) above the measured number, outside the stated range (below it).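

In this assay, benzyl in place of hydrogen on the oxygen gave no change at the digits printed from compound 3 to compound 4 (within the scatter), so the step seen on the core of compound 1 did not carry over to the core of compound 3: the same change on two cores in this assay, an at least 8.0-fold higher number (0.90 log units; beyond the scatter) from compound 1 to compound 2 and no change at the digits printed (within the scatter) from compound 3 to compound 4, at least 8.0-fold (0.90 log units) apart, beyond the scatter of two such steps

From the compounds shown here alone, for compound 2, the value > 20 ug/mL is a limit of the assay, and the size of the first step stays open.

These two pairs show that the outcome of this change differs between these two cores, but they do not show which difference between the cores goes with that, or how the change would read on any further core.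

Going by these compounds, it remains open how a group other than benzyl on that oxygen, such as methyl, acetyl or a chain ending in an amine or a carboxylic acid, would read on each core. On these data alone, it also remains open whether any such group would give the same step on both.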